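Amine change on the shared core: from compound 2 toward compound 3

The source may hold more compounds than are shown below. What is called first, only, known or untested is meant among the compounds shown, and "the series" means these compounds.

Measured so far:
- compound 1, `CCC(CC)Nc1nc(C)nc2c(-c3c(C)cc(N(C)C)nc3C)c(C)nn12`; in an assay on cell membranes for displacement of a labelled ligand from corticotropin-releasing factor receptor 1 (Rattus norvegicus) (a lower number here means a stronger inhibitor, a higher number a weaker inhibitor), compound 1 gives 25.6 nM
- compound 2, `CCCCN(CC)c1nc(C)nc2c(-c3ccc(OC)nc3C)c(C)nn12`; in this assay compound 2 gives 4.9 nM

Compound 2 stands at the lowest of the two numbers; compound 1 sits at a higher number, and the two values lie beyond the scatter of each other. For the measured compounds named here, the two compounds differ in more than one place, so no single step is isolated between them.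

Compound 3, `CCC[C@H](C)Nc1nc(C)nc2c(-c3ccc(OC)nc3C)c(C)nn12`, is not yet measured. It differs from compound 2 in one place: (1-methylbutyl)amino in place of butyl(ethyl)amino on an aromatic carbon. Going by the values given here, no measured pair shows this change on its own. Compound 1 also carries an amine bearing a hydrogen on its core, but with a different aryl group, so its value bears only loosely on this step.

For compound 3 a small move toward a higher number is expected, at or near the edge of the scatter, estimated as a 1.6-fold higher number from compound 2 to compound 3 (0.21 log units; within the scatter). Compound 3 is expected at 8 nM, with a range of 2.5 nM to 30 nM.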

Compound 3, half-maximal inhibitory concentration: 4.5 nM
Beside the measured number, compound 3's estimate is 1.8-fold (0.25 log units) above it; the measured number falls inside the stated range.
By their numbers in this assay, from the lowest: compounds 3 and 2 (each within the scatter of the next); then compound 1.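

In this assay, putting (1-methylbutyl)amino in place of butyl(ethyl)amino on the aromatic carbon between two ring nitrogen atoms gives a 1.1-fold lower number from compound 2 to compound 3 (0.04 log units; within the scatter), so the two compounds read alike. For the compounds shown here, this is the first single-place step, and it shows that this position on the shared core tolerates an amine with one hydrogen-bond donor and one defined stereocentre as well as one with no donor. Nothing available accounts for this equivalence.

From the compounds shown here alone, the opposite stereoisomer of (1-methylbutyl)amino remains open, so the contribution of the defined stereocentre cannot be read. Also open, going by these compounds, is how a cyclic amine such as morpholine or a longer chain such as (1-methylhexyl)amino would read at this position on the same core.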